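The source may hold more compounds than are shown below. What is called first, only, known or untested is meant among the compounds shown, and "the series" means these compounds.

Measured compounds in a functional assay on CHO cells for antagonist activity at Glucagon receptor (Homo sapiens), read by cAMP accumulation, with stated times of 30 min and 45 min; on this read-out lower numbers stand for stronger inhibition and higher numbers for weaker inhibition:
compound 1, `CC(C)(C)[C@H]1CC[C@]2(CC1)N=C(c1ccc(C(F)(F)F)cc1)C(=O)N2Cc1ccc(C(=O)NCCC(=O)O)cc1`, gives 800 nM;
compound 2, `CC(C)(C)[C@H]1CC[C@]2(CC1)N=C(c1ccc(OC(F)(F)F)cc1)C(=O)N2Cc1ccc(C(=O)NCCC(=O)O)cc1`, gives 1900 nM;
compound 3, `CC(C)(C)[C@H]1CC[C@]2(CC1)N=C(c1ccc(Cl)c(Cl)c1)C(=O)N2Cc1ccc(C(=O)NCCC(=O)O)cc1`, gives 1600 nM.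

Compound 3 sits close to compound 2 in this assay, the step being a 1.2-fold lower number from compound 2 to compound 3 (0.07 log units; within the scatter), and it is also not separated from compound 1, since the step is a 2.0-fold higher number from compound 1 to compound 3 (0.30 log units; within the scatter). Of the three measured steps, only a 2.4-fold higher number from compound 1 to compound 2 (0.38 log units; beyond the scatter) reaches beyond the scatter, and it concerns a swap on the aryl ring rather than removal of a substituent.

Compound 4, `CC(C)(C)[C@H]1CC[C@]2(CC1)N=C(c1cccc(Cl)c1)C(=O)N2Cc1ccc(C(=O)NCCC(=O)O)cc1`, differs from compound 3 by hydrogen in place of chloro on an aromatic carbon. Among the compounds with values here, no measured step removes a single chloro from this ring, so the two whole-aryl swaps, a 2.0-fold higher number from compound 1 to compound 3 (0.30 log units; within the scatter) and a 1.2-fold lower number from compound 2 to compound 3 (0.07 log units; within the scatter), are the nearest guide, and both stayed within the scatter. The change from compound 3 to compound 4 is therefore expected to shift the number in this assay only a little, if at all, with a slight lean toward a higher number because compound 1, the most substituted aryl variant, gave 800 nM, the lowest number of the set. This expectation corresponds to a step of a 1.6-fold higher number from compound 3 to compound 4 (0.19 log units; within the scatter). Compound 4 is expected to give about 2500 nM, within a range of 1000 nM to 6500 nM.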

Compound 4, half-maximal inhibitory concentration: 770 nM
Compound 4: the middle estimate sits 3.2-fold (0.51 log units) above what was measured; measured number outside the range, below it.
By their numbers in this assay, from the lowest: compounds 4, 1, 3 and 2 (each within the scatter of the next, the first and the last beyond it).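

In this assay, hydrogen in place of chloro on an aromatic carbon, para to a large group and ortho to a chloro group, gives a step beyond the scatter, a 2.1-fold lower number from compound 3 to compound 4 (0.32 log units; beyond the scatter), so the 3,4-dichlorophenyl to 3-chlorophenyl change lowers the number rather than leaving it in place. The 3-chlorophenyl group also stands apart from 4-(trifluoromethoxy)phenyl, with a 2.5-fold lower number from compound 2 to compound 4 (0.39 log units; beyond the scatter), but it cannot be separated from 4-(trifluoromethyl)phenyl, with a 1.0-fold lower number from compound 1 to compound 4 (0.02 log units; within the scatter), so a hydrogen on this carbon does as well here as a trifluoromethyl group there. Nothing shown gives a reason for the lower number on losing this chloro.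

The compounds shown leave open whether the remaining chloro matters, since a plain phenyl ring, or a fluoro, methoxy or nitrile group on that same carbon, would test how far this result extends. They also leave open whether the step holds with another group in place of the tert-butyl group or the carboxylic acid, such as a tetrazole.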